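A few compounds are considered here, and "the series" means these few. Any claim that something is new, unique, unknown or untested is made for them only; others in the source may bear on it.

Measured in a functional assay on NCI-H522 cells (Homo sapiens) for inhibition, read by sulforhodamine B assay, with a stated time of 48 h; on this read-out lower numbers stand for stronger inhibition of growth and higher numbers for weaker inhibition of growth:
Compound 1 `O=C(Nc1cccc(-n2cc(-c3ccncc3)c(-c3ccc(Cl)c(O)c3)n2)c1)Nc1cccc(C(F)(F)F)c1`: 14500 nM
Compound 2 `COc1cc(-c2nn(-c3cccc(NC(=O)Nc4cc(C(F)(F)F)cc(C(F)(F)F)c4)c3)cc2-c2ccncc2)ccc1Cl`: 1800 nM
Compound 3 `COc1cc(-c2nn(-c3cccc(NC(=O)Nc4cccc(C(F)(F)F)c4)c3)cc2-c2ccncc2)ccc1Cl`: 2430 nM

Compound 3 stands second highest of the three numbers. Its nearest neighbour is compound 2, and the step of a 1.4-fold higher number from compound 2 to compound 3 (0.13 log units; within the scatter) lies within the scatter, so the two cannot be ranked against each other. Its furthest neighbour is compound 1, and the step of a 6.0-fold lower number from compound 1 to compound 3 (0.78 log units; beyond the scatter) is beyond the scatter; that step concerns the ring carrying the chloro and the oxygen, not the urea end.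

Compound 4 `COc1cc(-c2nn(-c3cccc(NC(=O)Nc4ccc(Cl)c(C(F)(F)F)c4)c3)cc2-c2ccncc2)ccc1Cl` differs from compound 3 in one place: chloro in place of hydrogen on an aromatic carbon. The change sits on the same terminal ring of the urea that was altered between compound 2 and compound 3, where a second trifluoromethyl gave only a 1.4-fold higher number from compound 2 to compound 3 (0.13 log units; within the scatter). Within the data shown here, no step among the measured compounds involves a chloro group on that ring, so the only bearing evidence is that one small step. The step of a 6.0-fold lower number from compound 1 to compound 3 (0.78 log units; beyond the scatter) concerns a different ring and is not taken as a guide here.

On that basis compound 4 is expected to give 1800 nM in this assay, with a range from 700 nM to 5000 nM. The expected step of a 1.4-fold lower number from compound 3 to compound 4 (0.13 log units; within the scatter) is a small one, not beyond the scatter.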

Compound 4, concentration for total growth inhibition: 6060 nM
Compound 4: middle estimate off by 3.4-fold (0.53 log units), on the low side, outside the stated range (above it).
By their numbers in this assay, from the lowest: compounds 2 and 3 (each within the scatter of the next); then compound 4; then compound 1.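

On the terminal ring of the urea, chloro in place of hydrogen, ortho to the trifluoromethyl group and para to a large group, gives a 2.5-fold higher number from compound 3 to compound 4 (0.40 log units; beyond the scatter) in this assay, which means weaker inhibition of growth. This is the first change on that ring to lie beyond the scatter: the only earlier change there, a second trifluoromethyl, gave a 1.4-fold higher number from compound 2 to compound 3 (0.13 log units; within the scatter), which lies within it, so the terminal ring is now shown not to be indifferent to every substituent. Nothing given here measures any property of these compounds that could account for the loss seen with chloro at this position.

As far as these compounds go, with only hydrogen and chloro seen at this position, it remains open whether a smaller fluoro, a methoxy or an amine placed there would also raise the number, or whether the effect is particular to chloro. From the compounds shown here alone, it is also open whether the same chloro step would be of similar size on the core of compound 1, which carries a hydroxyl where compound 3 carries a methoxy.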